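Dropping a Methoxy Group When the Start Is Already Inactive

The source may hold more compounds than are shown below. What is called first, only, known or untested is meant among the compounds shown, and "the series" means these compounds.

Compound 1 `COc1ccc(N(C)c2nccc(-c3ccncc3)n2)cc1` is the starting point. In a functional assay for inhibition, with Homo sapiens as the target (on this read-out lower numbers stand for stronger inhibition and higher numbers for weaker inhibition), compound 1 gives > 24000 nM, which is a limit of the measurement and not a number. A near relative, compound 2 `COc1ccc(N(C)c2nccc(-c3cccnc3)n2)cc1`, carries pyridin-3-yl in place of pyridin-4-yl on an aromatic carbon. In this assay compound 2 likewise gives > 24000 nM, again a limit rather than a number. The step that the two limits leave unreadable from compound 1 to compound 2 therefore cannot be read, as the limit of > 24000 nM in this assay, at which 2 of the 2 values shown sit, shows.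

Compound 3 `CN(c1ccccc1)c1nccc(-c2ccncc2)n1` differs from compound 1 by hydrogen in place of methoxy on an aromatic carbon. Going by the values given here, no measured step bears directly on this change, and the only measured step, from compound 1 to compound 2, is itself unreadable; there is thus nothing to show that dropping the methoxy would move the read-out far in either direction. Since compound 1 already sits at the limit in this assay, compound 3 is expected to remain there as well, with a step that the limit leaves unreadable from compound 1 to compound 3 that amounts to no change beyond the usual scatter. The estimate for compound 3 in this assay is 30000 nM, within the range 8000 nM to 120000 nM.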

Compound 3, half-maximal inhibitory concentration: > 24000 nM
Compound 3: a limit, no number; the forecaster's own chance of this, stated with the estimate: 85%; the middle value does not contradict the limit.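

The step from compound 1 to compound 3 cannot be read, as neither compound gives a number in this assay, only a limit: the limit of > 24000 nM in this assay, at which 3 of the 3 values shown sit. The compounds shown leave open whether hydrogen in place of methoxy, or pyridin-3-yl in place of pyridin-4-yl, changes inhibition at all, and which change to the shared core would give a measurable value.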